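The compounds below may be only part of what the source reports. "The series", "measured", "known", "first", "only" and "open" are said of these compounds alone.

Measured in a functional assay on SW480 cells (Homo sapiens) for antiproliferative activity, read by MTT assay, with a stated time of 48 h; a higher number here means a weaker inhibitor, a lower number a stronger inhibitor:
Compound 1 `CCCCCC(CCO)n1cnc2c(N)ncnc21`: > 50000 nM, a limit.
Compound 2 `CCCCCCCC(CCO)n1cnc2c(N)ncnc21`: > 50000 nM, a limit.
Compound 3 `CCCCCCCCC(CCO)n1cnc2c(Cl)ncnc21`: 1370 nM.

Going by the values given here, compound 3 holds the only actual number in this set. The other two compounds stop at the limit of > 50000 nM in this assay, at which 2 of the 3 values shown sit. Compound 4 `CCCCCCCCC(CCO)n1cnc2c(N)ncnc21` keeps the chain of compound 3 and differs by amino in place of chloro on an aromatic carbon. Among the compounds with values here, the one measured step, a step that the two limits leave unreadable from compound 1 to compound 2, runs between two limits and gives no size. Compound 2, which also carries amino, is a limit at > 50000 nM, so a clear weakening beyond the scatter is expected in this assay. The expected change is a 15-fold higher number from compound 3 to compound 4 (1.16 log units; beyond the scatter). For compound 4 the estimated value is 20000 nM, with an expected range of 5000 nM to 50000 nM.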

Compound 4, half-maximal inhibitory concentration: 20700 nM
For compound 4 the middle estimate is 1.0-fold (0.01 log units) below the measured one, and the stated range covers the measured number.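

With the chain held fixed, amino in place of chloro on an aromatic carbon gives, in this assay, a 15-fold higher number from compound 3 to compound 4 (1.18 log units; beyond the scatter). Among the amino compounds, the longer chain gives an at least 2.4-fold lower number from compound 2 to compound 4 (0.38 log units; beyond the scatter), and likewise an at least 2.4-fold lower number from compound 1 to compound 4 (0.38 log units; beyond the scatter). The step between the two shorter chains cannot be read: the limit of > 50000 nM in this assay, at which 2 of the 4 values shown sit.

As far as these compounds go, whether bromo or methoxy on that aromatic carbon would fall nearer to chloro or to amino stays open. So does whether a still longer chain would lower the number further.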